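A Methyl Removed Where Nothing Has Yet Registered

The compounds below may be only part of what the source reports. "The series", "measured", "known", "first", "only" and "open" are said of these compounds alone.

The measured compounds:
- compound 1 `CCC(C)C1NC(=O)N(C2CCCCC2)C1=O`: > 200000 nM
- compound 2 `CCC(C)C1NC(=O)N(C2CCCC2)C1=O`: > 200000 nM
- compound 3 `CC(C)C1NC(=O)N(C2CCCC2)C1=O`: > 200000 nM

All three were tested in a functional assay on L1210 cells (Mus musculus) for inhibition; a lower number here means a stronger inhibitor, a higher number a weaker inhibitor. For compound 1 the value is a limit of the assay, not a number. For compound 2 the value is likewise a limit. For compound 3 it is a limit as well. Compound 1 and compound 2 share the same kind of core but differ in how the ring attached to the nitrogen is built; that difference between the two cores is not broken down here. Compound 2 and compound 3 differ by hydrogen in place of methyl on a saturated chain carbon, two bonds along the chain from a saturated ring carbon, and the step between them is a step that the two limits leave unreadable from compound 2 to compound 3: since both values are limits, its size cannot be read.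

Compound 4 `CC(C)C1NC(=O)N(C2CCCCC2)C1=O` has not been measured. Among the compounds with values here, it differs from compound 1 by hydrogen in place of methyl on a saturated chain carbon, two bonds along the chain from a saturated ring carbon, the same change as the one from compound 2 to compound 3, made at the same place. Within the data shown here, because all three measured values sit at the limit of > 200000 nM in this assay, at which 3 of the 3 values shown sit, the one earlier example of this change gives no readable size, and nothing in the measured set points away from that limit. The step from compound 1 to compound 4 in this assay is therefore expected to be a step that the limit leaves unreadable from compound 1 to compound 4, resting on the limit for compound 1 at > 200000 nM. For compound 4 the estimate is 300000 nM, with a range from 100000 nM to 1000000 nM, and most likely the assay will again report only a limit.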

Compound 4, half-maximal inhibitory concentration: > 200000 nM
Compound 4: no number, only a limit; the forecaster's own chance of this, stated with the estimate: 85%; the middle value is on the limit's open side.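

In this assay compound 4 gives > 200000 nM, which is a limit of the assay and not a number. Compound 1 also has only a limit, so no size can be read for the step between compound 1 and compound 4. The set as a whole shows one result: the limit of > 200000 nM in this assay, at which 4 of the 4 values shown sit.

The compounds shown leave open whether the sec-butyl or isopropyl group, or the ring on the nitrogen, has any bearing on inhibition.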